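The compounds below may be only part of what the source reports. "The series", "measured", "known", "first", "only" and "open" are said of these compounds alone.

Notes on the series. All compounds share one core, varied at the carbonyl substituent and at the halogen of the 3-fluorophenyl or 3-chlorophenyl group. In an assay on HEK293 cells for negative allosteric modulation of metabotropic glutamate receptor 5 (Homo sapiens), read by FLIPR (on this read-out higher numbers stand for weaker inhibition and lower numbers for stronger inhibition), compound 1 `O=C(C1CCC(F)(F)CC1)N1CC(c2nc(-c3cccc(Cl)c3)no2)C1` gives > 10000 nM, a limit of the assay and not a number. Compound 2 `COC1CCN(C(=O)N2CC(c3nc(-c4cccc(Cl)c4)no3)C2)CC1` gives > 10000 nM in this assay, again a limit. Compound 3 `O=C(c1ccc(F)cc1)N1CC(c2nc(-c3cccc(F)c3)no2)C1` gives > 10000 nM in this assay, also a limit. Compound 3 thus stands at the limit together with the two other values, so the step that the two limits leave unreadable from compound 1 to compound 2 cannot be read. Compound 4 `O=C(c1ccc(F)cc1)N1CC(c2nc(-c3cccc(Cl)c3)no2)C1` differs from compound 3 by chloro in place of fluoro on an aromatic carbon. Among the measured compounds shown here, no measured step bears on this change; compounds 1 and 2, which also carry the 3-chlorophenyl group, sit at the limit of > 10000 nM in this assay, at which 3 of the 3 values shown sit. The step that the limit leaves unreadable from compound 3 to compound 4 is expected to be none beyond the scatter. Compound 4 is estimated at 15000 nM, range 4000 nM to 50000 nM, most likely reported again as a limit.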

Compound 4, half-maximal inhibitory concentration: 4000 nM
For compound 4 the middle estimate is 3.8-fold (0.57 log units) above the measured one; the range from low to high includes it.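

With the 4-fluorophenyl group held on the carbonyl carbon, chloro in place of fluoro on the aromatic carbon gives an at least 2.5-fold lower number from compound 3 to compound 4 (0.39 log units; beyond the scatter) in this assay. With the 3-chlorophenyl group held, 4-fluorophenyl on the carbonyl carbon gives an at least 2.5-fold lower number from compound 2 to compound 4 (0.39 log units; beyond the scatter) and an at least 2.5-fold lower number from compound 1 to compound 4 (0.39 log units; beyond the scatter). Among the compounds shown, neither change alone lifts a compound off the limit: compounds 1 and 2 carry only the chloro, compound 3 only the 4-fluorophenyl, and compound 4 both.

Open, on these data alone, is whether bromo or methyl in place of chloro, or a pyridyl group in place of 4-fluorophenyl, moves the value further.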